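A Second Change at the Amide Carbonyl

The source may hold more compounds than are shown below. What is called first, only, known or untested is meant among the compounds shown, and "the series" means these compounds.

Compound 1 `COc1cc(/C=C/C(=O)c2cccc(NC(=O)c3c(Cl)cccc3Cl)c2)ccc1O` and compound 2 `COc1cc(/C=C/C(=O)c2cccc(NC(=O)C(C)C)c2)ccc1O` share one core and differ only in the group on the amide carbonyl carbon. In a functional assay on HUVEC cells (Homo sapiens) for inhibition, tested at 5 ug/mL (on this read-out lower numbers stand for a weaker effect and higher numbers for a stronger effect at the one concentration tested), compound 1 gives 88%, while compound 2 gives 51%, which is the lowest of the two numbers at hand. Among the compounds with values here, the step of a number 37 percentage points lower from compound 1 to compound 2 (beyond the scatter) went with isopropyl in place of 2,6-dichlorophenyl on a carbonyl carbon, and it is the only measured step available.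

Compound 3 `COC(=O)C(=O)Nc1cccc(C(=O)/C=C/c2ccc(O)c(OC)c2)c1` is still to be measured. It differs from compound 2 by methoxycarbonyl in place of isopropyl on a carbonyl carbon. Within the data shown here, no measured compound carries a methoxycarbonyl group, so the step of a number 37 percentage points lower from compound 1 to compound 2 (beyond the scatter) bears on compound 3 only in showing that the group on this carbonyl carbon can shift the number by a large amount. As the group entering is again without a ring and of similar size to the one leaving, the author expects a step of a number 1 percentage points lower from compound 2 to compound 3 (within the scatter) from compound 2 to compound 3, not beyond the scatter, though with wide uncertainty. Compound 3 is therefore estimated at 50%, with a range from 25% to 75%.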

Compound 3, a percentage reported as inhibition, at one concentration (the size of the read-out at that concentration, not a potency): 20%
Beside the measured number, compound 3's estimate is 30 percentage points above it; the whole stated range lies above it.
By their numbers in this assay, from the lowest: compound 3; then compound 2; then compound 1.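

In this assay, the change from isopropyl to methoxycarbonyl on a carbonyl carbon whose other neighbour is an amide-type nitrogen gives a number 31 percentage points lower from compound 2 to compound 3 (beyond the scatter). Neither group carries a ring, so a large step at this position does not depend on a ring leaving, which the earlier pair could not show, and the similar heavy-atom counts of the two groups did not go with similar numbers. Set against the 2,6-dichlorophenyl group, methoxycarbonyl gives a number 68 percentage points lower from compound 1 to compound 3 (beyond the scatter), which makes compound 3 the lowest of the three and shows that this one position spans a wider range than the first pair revealed, while no measurement on hand explains why the numbers fall in this order.

The three compounds leave open whether the drop belongs to the methyl ester as a whole or to the carbonyl it places on the amide carbonyl, a question that a carboxylic acid, an ethoxycarbonyl group or a simple acetyl group at this carbon would bear on. They also leave open whether the high number of compound 1 needs its two chlorines, which an unsubstituted phenyl group in the same place would test.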